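Swapping isopropyl for propyl on an aromatic nitrogen

The compounds below may be only part of what the source reports. "The series", "measured", "known", "first", "only" and "open" are said of these compounds alone.

Compound 1 `COc1ccc(Nc2nccc(-c3c[nH]c4ccccc34)n2)c(OC)c1`: 600 nM
Compound 2 `COc1ccc(Nc2nccc(-c3cn(C(C)C)c4ccccc34)n2)c(OC)c1`: 3250 nM

Going by the values given here, in a functional assay on MV4-11 cells (Homo sapiens) for inhibition, read by resazurin assay, with a stated time of 72 h (on this read-out higher numbers stand for weaker inhibition of growth and lower numbers for stronger inhibition of growth), compound 2 stands highest of the two measured compounds, at 3250 nM, and its only neighbour is compound 1. Compound 3 `CCCn1cc(-c2ccnc(Nc3ccc(OC)cc3OC)n2)c2ccccc21` keeps the core of compound 2 and alters only the chain: propyl in place of isopropyl on an aromatic nitrogen. Among the compounds with values here, one measured step bears on this, a 5.4-fold higher number from compound 1 to compound 2 (0.73 log units; beyond the scatter), where isopropyl takes the place of hydrogen on the same aromatic nitrogen. That step shows that a change at this nitrogen can be seen in this assay, but it replaces hydrogen with a chain, so it does not directly measure a swap of one chain for another. Starting from compound 2 at 3250 nM, a smaller change is expected here, probably none beyond the scatter. The estimated change is a 1.3-fold lower number from compound 2 to compound 3 (0.11 log units; within the scatter). For compound 3, the estimated value is 2500 nM, with an expected range of 1000 nM to 6000 nM.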

Compound 3, concentration for 50% growth inhibition: 3620 nM
Compound 3: middle estimate off by 1.4-fold (0.16 log units), on the low side; the measured number falls inside the stated range.
By their numbers in this assay, from the lowest: compound 1; then compounds 2 and 3 (each within the scatter of the next).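

In this assay, propyl in place of isopropyl on the aromatic nitrogen gives a 1.1-fold higher number from compound 2 to compound 3 (0.05 log units; within the scatter) and so leaves the two chains indistinguishable, though one is branched and the other straight. The earlier step from hydrogen to isopropyl could have been specific to that one chain, yet propyl in place of hydrogen gives a 6.0-fold higher number from compound 1 to compound 3 (0.78 log units; beyond the scatter) as well. At this position, then, both chains give a higher number than hydrogen, and the arrangement of their carbon atoms makes no difference that can be read in this assay.

The compounds shown leave open how a smaller group such as methyl, a longer chain such as butyl, or a chain ending in an amine or a carboxylic acid would behave at this nitrogen. Nothing available explains the gap between hydrogen and the two chains.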